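The source may hold more compounds than are shown below. What is called first, only, known or untested is meant among the compounds shown, and "the series" means these compounds.

Compound 1 `CSS[C@H]1C[C@H](n2ccc(N)nc2=O)O[C@@H]1CO` gives 149000 nM in a functional assay on MOLT-4 cells (Homo sapiens) for cytotoxicity; a lower number here means a stronger inhibitor, a higher number a weaker inhibitor.
Compound 2 `Cc1cn([C@H]2C[C@H](SSC(Cl)(Cl)Cl)[C@@H](CO)O2)c(=O)[nH]c1=O` gives 55000 nM in this assay.
Compound 3 `CCCCSS[C@H]1C[C@H](n2cc(C)c(=O)[nH]c2=O)O[C@@H]1CO` gives 28000 nM in this assay.

Compound 3 has the lowest number of the three, but its gap to compound 2 is within the scatter; only its gap to compound 1, which carries a shorter chain on the outer sulfur and a different base, lies beyond it. Compound 4 `Cc1cn([C@H]2C[C@H](SSCCO)[C@@H](CO)O2)c(=O)[nH]c1=O` has not yet been measured. It differs from compound 3 by hydroxy in place of ethyl on a saturated chain carbon, two bonds along the chain from a sulfur. Among the measured compounds shown here, the only measured step that alters the group on the outer sulfur is a 2.0-fold lower number from compound 2 to compound 3 (0.29 log units; within the scatter), and that step stayed within the scatter. For the measured compounds named here, no measured step exchanges part of a carbon chain for a hydroxy group, so the direction of this change is not covered by the data. Given how little the chain on the sulfur has mattered so far, compound 4 is expected to give a number close to that of compound 3, most likely somewhat higher, as a 2.1-fold higher number from compound 3 to compound 4 (0.33 log units; beyond the scatter). Compound 4 is therefore estimated at 60000 nM, with a range from 20000 nM to 200000 nM.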

Compound 4, half-maximal inhibitory concentration: 128000 nM
Compound 4: middle estimate off by 2.1-fold (0.33 log units), on the low side; the range from low to high includes it.
By their numbers in this assay, from the lowest: compounds 3 and 2 (each within the scatter of the next); then compounds 4 and 1 (each within the scatter of the next).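

In this assay the group on the outer sulfur proves able to shift the number after all: hydroxy in place of ethyl, two bonds along the chain from a sulfur, gives a 4.6-fold higher number from compound 3 to compound 4 (0.66 log units; beyond the scatter) and so a modest weakening that lies beyond the scatter. The 2-hydroxyethyl group also separates from trichloromethyl, with a 2.3-fold higher number from compound 2 to compound 4 (0.37 log units; beyond the scatter) as a modest step beyond the scatter, whereas butyl and trichloromethyl could not be told apart. Among compounds 2, 3 and 4, which differ only in this group, the 2-hydroxyethyl compound therefore stands apart with the highest number of the three.

As far as these compounds go, whether this weakening is particular to the hydroxy group, or would also appear with an amine, a carboxylic acid or a longer chain ending in hydroxy, stays open, as does whether it would hold with the base of compound 1. Nothing available here explains the shift.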